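Butoxy to ethoxy in the alkoxy series

The compounds below may be only part of what the source reports. "The series", "measured", "known", "first", "only" and "open" are said of these compounds alone.

Values from a functional assay on A549 cells (Homo sapiens) for inhibition, read by sulforhodamine B assay, with a stated time of 48 h, tested at 50 uM (a higher number here means more inhibition of growth at the concentration tested, a lower number less inhibition of growth), so far are these
- compound 1 `CCCOc1ccc([C@@H]2CC(=O)c3cc(CC=C(C)C)c(OC)cc3O2)cc1` gives 43%
- compound 2 `COc1ccc([C@@H]2CC(=O)c3cc(CC=C(C)C)c(OC)cc3O2)cc1` gives 45%
- compound 3 `CCCCOc1ccc([C@@H]2CC(=O)c3cc(CC=C(C)C)c(OC)cc3O2)cc1` gives 37%

Compound 3 gives 37% and is not separated from the other two. The numbers show a number 6 percentage points lower from compound 1 to compound 3 (within the scatter) and a number 8 percentage points lower from compound 2 to compound 3 (within the scatter) with neither step beyond the scatter.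

Compound 4 `CCOc1ccc([C@@H]2CC(=O)c3cc(CC=C(C)C)c(OC)cc3O2)cc1` comes next. Its change from compound 3 is hydrogen in place of ethyl on a saturated chain carbon, two bonds along the chain from an oxygen on an aromatic ring and reads butoxy to ethoxy, with hydrogen in place of ethyl on a saturated chain carbon, two bonds along the chain from an oxygen on an aromatic ring.

The two steps above bear on this change, as compound 1 and compound 2 also lack the butoxy chain of compound 3. The remaining step, a number 2 percentage points higher from compound 1 to compound 2 (within the scatter) in size, separates neither of them. In this assay a small step upward is therefore expected, with nothing beyond the scatter. The expected step is a number 6 percentage points higher from compound 3 to compound 4 (within the scatter) on this estimate. For compound 4 the estimate is 43% with an expected range of 34% to 52% as the span.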

Compound 4, percent growth inhibition at one concentration: 37%
For compound 4 the middle estimate is 6 percentage points above the measured one, within the range that was stated.
By their numbers in this assay, from the lowest: compounds 3, 4, 1 and 2 (each within the scatter of the next).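

In this assay, butoxy to ethoxy gives no change at the digits printed from compound 3 to compound 4 (within the scatter), while the other two new steps are a number 8 percentage points lower from compound 2 to compound 4 (within the scatter) and a number 6 percentage points lower from compound 1 to compound 4 (within the scatter), so the length of the alkoxy chain separates none of the four compounds. Replacing ethyl with hydrogen at this position reads alike on a second pair: the same change on two cores in this assay, a number 2 percentage points higher (within the scatter) from compound 1 to compound 2 and no change at the digits printed (within the scatter) from compound 3 to compound 4, 2 percentage points apart, within the scatter of two such steps

The reverse comparison, lengthening the chain by the same change on two pairs, also holds together: the same change on two cores in this assay, a number 6 percentage points lower (within the scatter) from compound 1 to compound 3 and a number 8 percentage points lower (within the scatter) from compound 2 to compound 4, 2 percentage points apart, within the scatter of two such steps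

On these data alone, whether any change at this position can move growth inhibition beyond the scatter remains open. A longer chain, an amine or a carboxylic acid in place of the alkoxy chain would test this, and the readings at a single concentration say nothing about the response at other concentrations.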